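The source may report more compounds than this note shows. Statements on the series, on what has been measured and on what is new or still open speak of the compounds shown alone.

Working notes on the series. Compound 2 `C=C1CC[C@@H]2[C@](C)(CO)[C@H](O)CC[C@@]2(C)[C@@H]1C/C=C1/C(=O)OC[C@H]1Oc1cccc2ccc(C)nc12` and compound 1 `C=C1CC[C@@H]2[C@](C)(CO)[C@H](O)CC[C@@]2(C)[C@@H]1C/C=C1/C(=O)OC[C@H]1Oc1c(Cl)cc(Cl)c2cccnc12` share one core and differ in a single place, (5,7-dichloroquinolin-8-yl in place of 2-methylquinolin-8-yl on an oxygen on a saturated carbon). Compound 3 `C=C1CC[C@H]2[C@@](C)(CCC(=O)[C@@]2(C)COC(C)=O)[C@@H]1C/C=C1/C(=O)OC[C@@H]1Oc1cccc2ccc(C)nc12` is built on another core; the difference between the core of compound 3 and the core of compound 2 is not broken down here. Compound 4 `C=C1CC[C@H]2[C@@](C)(CCC(=O)[C@@]2(C)COC(C)=O)[C@@H]1C/C=C1/C(=O)OC[C@@H]1Oc1c(Cl)cc(Cl)c2cccnc12` has not been measured and stands to compound 3 as compound 1 stands to compound 2, namely (5,7-dichloroquinolin-8-yl in place of 2-methylquinolin-8-yl on an oxygen on a saturated carbon). The surroundings of the place are the same in both pairs, so this is the same change made twice.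

In an ADME assay on SNB-19 cells (Homo sapiens) for cytotoxicity, read by MTT assay, with a stated time of 24 h (on this read-out lower numbers stand for higher toxicity in this test and higher numbers for lower toxicity in this test), compound 2 gives > 100000 nM, and this is a limit of the assay, not a number. In this assay compound 1 gives 85200 nM. The step of an at least 1.1-fold lower number from compound 2 to compound 1 (0.06 log units; that floor lies within the scatter) rests on the limit of > 100000 nM in this assay, at which 1 of the 3 values shown sits, and so marks only a floor for what the change did. In this assay compound 3 gives 51700 nM; set against compound 1 this is within the scatter, so no order between the two is read.

Going by the values given here, for compound 4 the same change is expected to move the number little, since the only measured instance, an at least 1.1-fold lower number from compound 2 to compound 1 (0.06 log units; that floor lies within the scatter), lies within the scatter and its true size is not fixed. The expected step is a 1.0-fold lower number from compound 3 to compound 4 (0.01 log units; within the scatter). Compound 4 is therefore estimated at 50000 nM in this assay, with a likely range from 22000 nM to 100000 nM, and a real chance that only a limit is returned.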

Compound 4, half-maximal cytotoxic concentration: 72000 nM
Compound 4: middle estimate off by 1.4-fold (0.16 log units), on the low side; low and high end bracket the measured number.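

In this assay, 5,7-dichloroquinolin-8-yl in place of 2-methylquinolin-8-yl on an oxygen on a saturated carbon gives a 1.4-fold higher number from compound 3 to compound 4 (0.14 log units; within the scatter), and the comparison with the earlier instance reads: the same change on two cores in this assay, an at least 1.1-fold lower number (0.06 log units; that floor lies within the scatter) from compound 2 to compound 1 and a 1.4-fold higher number (0.14 log units; within the scatter) from compound 3 to compound 4; the limit leaves it open whether they differ Neither step is printed as beyond the scatter, so on these two cores the change shows no clear effect on the number in either setting, and nothing here marks one core as responding differently from the other; this is a statement about two pairs only, not a rule for the series. It does not show that the two steps are equal, or even that they share a direction, and the earlier step is known only as a floor set by a limit of the assay: the limit of > 100000 nM in this assay, at which 1 of the 4 values shown sits.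

The compounds shown leave open which part of the difference between the two cores, if any, bears on the number, since that difference is not broken down into single changes. They also leave open what happens in this assay when the group on that oxygen is something other than these two quinolin-8-yl groups, such as an amine, a carboxylic acid or a longer chain.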